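Amine variation on a shared amide core, cytotoxicity notes

This account rests on a few compounds, and the source may have more. Where it says the series, first, only, none or still open, it means among the compounds named here.

Compound 3 `COC(=O)CNc1c(C(=O)NCc2ccc(F)cc2)nc(Br)c2cccnc12` carries the ((methoxycarbonyl)methyl)amino group on an aromatic carbon of the shared core. In a functional assay on HCT-116 cells (Homo sapiens) for cytotoxicity, read by MTT assay, with a stated time of 72 h (a higher number here means a weaker inhibitor, a lower number a stronger inhibitor), compound 3 gives > 10000 nM, which is a limit of the assay and not a number. Compound 1 `CS(=O)(=O)Oc1c(C(=O)NCc2ccc(F)cc2)nc(Br)c2cccnc12` bears (methylsulfonyl)oxy at that aromatic carbon. In this assay compound 1 gives > 20000 nM, again a limit rather than a measured value. For compound 2 `N[C@H]1CC[C@H](Nc2c(C(=O)NCc3cccc(C(F)(F)F)c3)nc(Br)c3cccnc23)CC1` the entry in this assay reads "not determined" (no result reported).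

Among the measured compounds shown here, the only step between measured compounds, a step that the two limits leave unreadable from compound 1 to compound 3, cannot be read in size or direction because its two ends sit at the limit of > 10000 nM in this assay, at which 1 of the 3 values shown sits, and (the limit of > 20000 nM in this assay, at which 1 of the 3 values shown sits). For the measured compounds named here, compound 3 thus stands at a limit, with one further limit and one empty entry beside it; no compound in the set has a number.

Compound 4 `N[C@H]1CC[C@H](Nc2c(C(=O)NCc3ccc(F)cc3)nc(Br)c3cccnc23)CC1` differs from compound 3 by 4-aminocyclohexyl in place of (methoxycarbonyl)methyl on a nitrogen on an aromatic ring. Going by the values given here, no measured step bears on this change, and the sole measured step offers neither size nor direction. The expected step of a number no higher from compound 3 to compound 4 (the limit leaves the size open) is therefore taken as no more than scatter, in no fixed direction. Compound 4 is expected to give about 10000 nM in this assay, with a range from 2000 nM to 40000 nM, and a strong chance that only a limit is reported.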

Compound 4, half-maximal inhibitory concentration: 7000 nM
Beside the measured number, compound 4's estimate is 1.4-fold (0.15 log units) above it; low and high end bracket the measured number.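

In this assay, among the compounds shown here, compound 4 gives the first single number, 7000 nM, so the (4-aminocyclohexyl)amino group brings this aromatic carbon of the shared core within the measurable range. Set against (methylsulfonyl)oxy at the same carbon, the change gives an at least 2.8-fold lower number from compound 1 to compound 4 (0.45 log units; beyond the scatter), and that figure is only a floor, the entry for compound 1 being a limit of the assay: the limit of > 20000 nM in this assay, at which 1 of the 4 values shown sits. Set against (methoxycarbonyl)methyl on the nitrogen, 4-aminocyclohexyl gives an at least 1.4-fold lower number from compound 3 to compound 4 (0.15 log units; that floor lies within the scatter), so this comparison alone secures no change beyond the scatter, although the number may still lie well under the entry for compound 3.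

A plain cyclohexyl group or an open 4-aminobutyl chain on that nitrogen would separate the contribution of the ring from that of the terminal amine, and neither stands among the compounds shown. How far compound 4 truly lies from compound 3 also remains open, the entry for compound 3 being a limit of the assay: the limit of > 10000 nM in this assay, at which 1 of the 4 values shown sits.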